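Chlorine shift from 3-chlorobenzyl to 4-chlorobenzyl

The source may hold more compounds than are shown below. What is called first, only, known or untested is meant among the compounds shown, and "the series" means these compounds.

Within the data shown here, in a functional assay on HeLa cells (Homo sapiens) for antiproliferative activity, read by MTT assay, with a stated time of 48 h (a lower number here means a stronger inhibitor, a higher number a weaker inhibitor), three compounds have numbers so far. Compound 1 `Clc1ccc(CSc2nnc(-c3cnccn3)o2)cc1` gives 24600 nM and compound 2 `Fc1ccccc1CSc1nnc(-c2cnccn2)s1` gives 32700 nM while compound 3 `Clc1cccc(CSc2nnc(-c3cnccn3)n2-c2ccccc2)c1` gives 13500 nM on the same read-out. Compound 3 cannot be separated from compound 1 within the scatter, and it stands beyond the scatter on the stronger side of compound 2. Among the measured compounds shown here, these three differ in more than one place, so no measured pair isolates a single change.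

Next comes compound 4 `Clc1ccc(CSc2nnc(-c3cnccn3)n2-c2ccccc2)cc1`, which carries 4-chlorophenyl in place of 3-chlorophenyl on a saturated chain carbon bound to a sulfur. For the measured compounds named here, with no measured step to lean on and the same atoms joined differently, no step beyond the scatter is expected in this assay and no direction is favoured. The expected step of a 1.0-fold higher number from compound 3 to compound 4 (0.02 log units; within the scatter) is estimated to stay within the scatter. Compound 4 is estimated at 14000 nM with an expected range from 6500 nM to 30000 nM for the coming measurement.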

Compound 4, half-maximal inhibitory concentration: > 50000 nM
Compound 4: no number, only a limit (the forecaster's own chance of this, stated with the estimate: 2%); at least 3.5-fold (0.55 log units) between middle value and limit.
By their numbers in this assay, from the lowest: compounds 3, 1 and 2 (each within the scatter of the next, the first and the last beyond it). At a limit, above all of these: compound 4.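

Moving the chlorine from 3-chlorobenzyl to 4-chlorobenzyl is the first change in the series made in one place only, and in this assay it gives an at least 3.7-fold higher number from compound 3 to compound 4 (0.56 log units; beyond the scatter). For compound 4, the reading of > 50000 nM is a limit of the assay and not a number. With the rest of compound 3 held fixed, the exchange of 3-chlorophenyl for 4-chlorophenyl on a saturated chain carbon bound to a sulfur is therefore enough to carry the step beyond the scatter, though its full size cannot be read: the limit of > 50000 nM in this assay, at which 1 of the 4 values shown sits.

Going by these compounds, whether the same chlorine shift has a similar outcome on the cores of compound 1 and compound 2 remains open. Also open, on these data alone, is how either chlorobenzyl group compares with unsubstituted benzyl or with a benzyl group carrying a methoxy group or a carboxylic acid.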